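Dropping the second basic side chain of compound 2

This account rests on a few compounds, and the source may have more. Where it says the series, first, only, none or still open, it means among the compounds named here.

The set opens with compound 1 `Clc1ccc(OCc2nc3ccccc3n2CCN2CCCCC2)cc1`. In an assay on isolated protein for binding affinity to Neuropeptide Y receptor type 1 (Homo sapiens) (a lower number here means a stronger inhibitor, a higher number a weaker inhibitor), compound 1 gives > 100000 nM, and that figure is a limit of the assay rather than a number. Compound 2 `Clc1ccc(OCc2nc3c(OCCC4CCCNC4)cccc3n2CCCC2CCCNC2)cc1` carries two side chains that each end in a piperidine ring, and in this assay compound 2 gives 18 nM. Going by the values given here, this is the only true number measured so far, since the one other result sits at the limit (the limit of > 100000 nM in this assay, at which 1 of the 2 values shown sits). Compound 3 `Clc1ccc(OCc2nc3ccccc3n2CCCC2CCCNC2)cc1` awaits testing. It differs from compound 2 by hydrogen in place of 2-(piperidin-3-yl)ethoxy on an aromatic carbon. Among the compounds with values here, no measured pair in the set differs in a single place, so no step can be read off directly, and compound 1, which also lacks the ether chain, differs in two places at once. The author nonetheless expects the step of a 33-fold higher number from compound 2 to compound 3 (1.52 log units; beyond the scatter) to be a loss beyond the scatter. For compound 3 the estimated value is 600 nM, within a range from 60 nM to 8000 nM.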

Compound 3, inhibition constant: 700 nM
For compound 3 the middle estimate is 1.2-fold (0.07 log units) below the measured one, within the range that was stated.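

Taking the 2-(piperidin-3-yl)ethoxy chain off the aromatic carbon gives the first direct reading of this position: in this assay the change is a 39-fold higher number from compound 2 to compound 3 (1.59 log units; beyond the scatter), yet compound 3 still gives a measurable 700 nM, so the core keeps measurable binding without that chain. The side chain on the aromatic nitrogen can now be read as well, since (piperidin-3-yl)methyl in place of piperidin-1-yl on the saturated chain carbon gives an at least 140-fold lower number from compound 1 to compound 3 (2.15 log units; beyond the scatter). The result for compound 1 is a limit of the assay rather than a number, so that step has no upper end: the limit of > 100000 nM in this assay, at which 1 of the 3 values shown sits.

On these data alone, what remains open is how much of the chain is needed at the aromatic carbon, for instance whether a methoxy group or an ethoxy chain ending in a primary amine would recover part of the step. Going by these compounds alone, the change on the saturated chain carbon is also seen only in compounds lacking the ether chain.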